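Amide versus sulfonamide on the ring amine

The source may hold more compounds than are shown below. What is called first, only, known or untested is meant among the compounds shown, and "the series" means these compounds.

Compound 1 `CC(=O)N[C@H]1[C@H]([C@@H](O)[C@H](O)CNC(=O)c2ccc(Cl)cc2)O[C@@](OCc2cccc(F)c2F)(C(=O)O)C[C@@H]1O`: 2400 nM in an in vitro assay on cells for binding affinity to myelin-associated glycoprotein (Mus musculus), read by surface plasmon resonance; a lower number here means tighter binding, a higher number weaker binding.
Compound 2 `O=C(CCl)N[C@H]1[C@H]([C@@H](O)[C@H](O)CNC(=O)c2ccc(Cl)cc2)O[C@@](OCc2cccc(F)c2F)(C(=O)O)C[C@@H]1O`: 2100 nM in this assay.
Compound 3 `CS(=O)(=O)N[C@H]1[C@H]([C@@H](O)[C@H](O)CNC(=O)c2ccc(Cl)cc2)O[C@@](OCc2cccc(F)c2F)(C(=O)O)C[C@@H]1O`: 17000 nM in this assay.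

Compound 3 stands at the high end of the three numbers: a 7.1-fold higher number from compound 1 to compound 3 (0.85 log units; beyond the scatter) and an 8.1-fold higher number from compound 2 to compound 3 (0.91 log units; beyond the scatter). Compound 4 `COCC(=O)N[C@H]1[C@H]([C@@H](O)[C@H](O)CNC(=O)c2ccc(Cl)cc2)O[C@@](OCc2cccc(F)c2F)(C(=O)O)C[C@@H]1O` differs from compound 3 by (methoxymethyl)carbonyl in place of methylsulfonyl on an amine nitrogen, which restores an amide of the kind carried by compounds 1 and 2. Those two steps bear directly on it; both were modest and point the same way. The step of a 1.1-fold lower number from compound 1 to compound 2 (0.06 log units; within the scatter) shows that what sits on the acetyl carbon leaves the number within the scatter, so the methoxymethyl group is not expected to matter. A step back down of roughly that size is therefore expected: a 7.4-fold lower number from compound 3 to compound 4 (0.87 log units; beyond the scatter). Compound 4 is estimated at 2300 nM in this assay, within 1100 nM to 5000 nM.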

Compound 4, dissociation constant: 2300 nM
Beside the measured number, compound 4's estimate shows no gap at the digits printed; the measured number falls inside the stated range.
By their numbers in this assay, from the lowest: compounds 2, 4 and 1 (each within the scatter of the next); then compound 3.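

In this assay, the step of a 1.0-fold lower number from compound 1 to compound 4 (0.02 log units; within the scatter) and the step of a 1.1-fold higher number from compound 2 to compound 4 (0.04 log units; within the scatter) both lie within the scatter, so hydrogen, chloro and methoxy on the saturated chain carbon bound to the carbonyl carbon cannot be told apart. The step of a 7.4-fold lower number from compound 3 to compound 4 (0.87 log units; beyond the scatter) shows that the gap to methylsulfonyl on the amine nitrogen also holds for a (methoxymethyl)carbonyl amide, leaving compound 3 alone apart from the other three. No measured evidence on the origin of that gap is available.

On these data alone, whether an amine, a carboxylic acid or a longer chain on that carbon would also stay within the scatter remains open. So does whether ethylsulfonyl on the amine nitrogen would match compound 3.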